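Changing the Formyl Group on Compound 1

This account rests on a few compounds, and the source may have more. Where it says the series, first, only, none or still open, it means among the compounds named here.

- compound 1 `CCCCc1ccc2[nH]c(-c3ccc(C(F)(F)F)cc3)c(C=O)c2c1`: 33 nM
- compound 2 `CCCCCc1ccc2[nH]c(-c3ccc(C(F)(F)F)cc3)c(C=O)c2c1`: 42 nM
- compound 3 `CCCCCCc1ccc2[nH]c(-c3ccc(C(F)(F)F)cc3)c(C=O)c2c1`: 43 nM

These values come from a functional assay on MDA-MB-231 cells (Homo sapiens) for antiproliferative activity, with a stated time of 4 days; on this read-out higher numbers stand for weaker inhibition and lower numbers for stronger inhibition. Compound 1 gives 33 nM, and the scatter of repeated measurements leaves it level with the other two compounds.

The unmeasured compound 4 `CCCCc1ccc2[nH]c(-c3ccc(C(F)(F)F)cc3)c(/C=N\C)c2c1` keeps the butyl chain of compound 1 and alters another part of the molecule. The change is a group of 3 heavy atoms (2 carbon, 1 nitrogen; no ring) in place of a group of 2 heavy atoms (1 carbon, 1 oxygen; no ring), on an aromatic carbon. The formyl group leaves an aromatic carbon of a five-membered aromatic ring with 1 nitrogen, and the new group takes its place.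

The measured steps all lie on the saturated chain: a 1.3-fold higher number from compound 1 to compound 2 (0.10 log units; within the scatter), a 1.3-fold higher number from compound 1 to compound 3 (0.11 log units; within the scatter) and a 1.0-fold higher number from compound 2 to compound 3 (0.01 log units; within the scatter). Each is small, but none touches the formyl group, so they give no direct measure of this replacement. Among the compounds with values here, they show only that the chain changes tried here left the number within the scatter. With no measured replacement of the formyl group, the starting point is the value of compound 1, 33 nM, and the forecast must stay loose.

A modest move towards a higher number in this assay is expected, meaning somewhat weaker inhibition, although no change at all would not surprise. The expected step is a 1.8-fold higher number from compound 1 to compound 4 (0.26 log units; within the scatter). The estimate for compound 4 is 60 nM, within an expected range of 15 nM to 250 nM.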

Compound 4, half-maximal inhibitory concentration: 32 nM
Estimate against measurement, compound 4: 1.9-fold (0.27 log units) above; the range from low to high includes it.
By their numbers in this assay, from the lowest: compounds 4, 1, 2 and 3 (each within the scatter of the next).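

In this assay, the formyl group on an aromatic carbon of the five-membered aromatic ring with 1 nitrogen can be replaced by the group of 3 heavy atoms (2 carbon, 1 nitrogen) with a 1.0-fold lower number from compound 1 to compound 4 (0.01 log units; within the scatter). Within the data shown here, this is the first direct reading at this position, since the earlier steps changed only the saturated chain, and it shows that for this pair the oxygen of the formyl group can give way to nitrogen and an extra carbon while the number stays level, with both groups counting one double bond outside aromatic rings, one hydrogen-bond acceptor and no hydrogen-bond donors. Nothing available here accounts for why the two groups read alike.

On these data alone, how much variety this position accepts remains open, as a nitrile, a carboxylic acid or an amine in place of the formyl group could give a very different number or a similar one. As far as these compounds go, it is also open whether the same replacement would stay level on the pentyl chain of compound 2 or the hexyl chain of compound 3, as this single pair carries the butyl chain.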